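A few compounds are considered here, and "the series" means these few. Any claim that something is new, unique, unknown or untested is made for them only; others in the source may bear on it.

Compound 1 `CCCn1c(NC(=O)c2cccnn2)nc2cc(C(N)=O)cc(OC)c21`: > 100000 nM
Compound 2 `CCCn1c(NC(=O)c2cncn2C)nc2cc(C(N)=O)cc(OC)c21`: > 100000 nM
Compound 3 `COc1cc(C(N)=O)cc2nc(NC(=O)c3cccnn3)n(CCCNC(=O)OCc3ccccc3)c12`: > 100000 nM

In an assay for activation of interferon regulatory factor 3 (Homo sapiens), read by a luciferase reporter, with a stated time of 20 h (on this read-out higher numbers stand for an effect only at larger amounts of compound and lower numbers for an effect already at smaller amounts), compound 1 gives > 100000 nM, which is a limit of the assay and not a number. Compound 2 gives > 100000 nM in this assay, again a limit. Compound 3 also returns only a limit, > 100000 nM. All three sit at the limit of > 100000 nM in this assay, at which 3 of the 3 values shown sit, and for that reason both measured steps, a step that the two limits leave unreadable from compound 1 to compound 2 and a step that the two limits leave unreadable from compound 1 to compound 3, have no readable size. Compound 3 thus stands on no number at all, only on the same limit as its two neighbours.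

Compound 4 `COc1cc(C(N)=O)cc2nc(NC(=O)c3cccn3C)n(CCCNC(=O)OCc3ccccc3)c12` differs from compound 3 by 1-methyl-1H-pyrrol-2-yl in place of pyridazin-3-yl on a carbonyl carbon. Within the data shown here, no measured step carries this exact change. The nearest comparison is the exchange of the ring on the carbonyl carbon from compound 1 to compound 2, which left both ends at the limit, so nothing in the measured data points to an effect that would become readable here. Compound 4 is expected to give about 100000 nM in this assay, within 30000 nM to 300000 nM. The step from compound 3 to compound 4 is estimated as a number no higher from compound 3 to compound 4 (the limit leaves the size open), with the most likely outcome a further limit rather than a number.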

Compound 4, half-maximal effective concentration: > 100000 nM
Compound 4 gave a limit, no number; the forecaster's own chance of this, stated with the estimate: 70%; the middle value sits exactly at the limit.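

No step can be read between compound 3 and compound 4, since both give only a limit and no number in this assay: the limit of > 100000 nM in this assay, at which 4 of the 4 values shown sit.

The compounds shown leave open whether any ring on the carbonyl carbon, with or without the (benzyloxycarbonyl)amino group on the chain, gives a number rather than a limit in this assay.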